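Swapping methoxy for trifluoromethyl on a bicyclic core

The source may report more compounds than this note shows. Statements on the series, on what has been measured and on what is new or still open speak of the compounds shown alone.

Measured so far:
compound 1, `Brc1cccc(-c2nc3ncccc3o2)c1`, 23%
compound 2, `COc1ccccc1-c1nc2ncccc2o1`, 9%
compound 3, `FC(F)(F)Oc1ccc(-c2nc3ncccc3o2)cc1`, 0%

All three compounds share one core and differ only in the substituent on the attached six-membered aromatic ring of carbon only. In a functional assay on the whole organism for inhibition, with Rattus norvegicus as the target, at a dose of 30 mg/kg (a lower number here means less inhibition, a higher number more inhibition at the dose given (going by the name of the read-out)), compound 1 gives 23%, compound 2 gives 9% and compound 3 gives 0%. Compound 2 stands second highest of the three numbers: its value lies within the usual scatter of that of compound 3, and beyond the scatter below that of compound 1. The inhibition in this assay is low for all three compounds at this dose.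

Compound 4, `FC(F)(F)c1ccccc1-c1nc2ncccc2o1`, has not been measured. It differs from compound 2 in one place: trifluoromethyl in place of methoxy on an aromatic carbon. For the measured compounds named here, no pair of measured compounds differing in just one place is available, so there is no directly comparable step. Given that all three measured values are low, the step in this assay is expected to be small, with no clear direction beyond the scatter. Compound 4 is expected to give about 10%, in the range 0% to 28%. That estimate means a step of a number 1 percentage points higher from compound 2 to compound 4 (within the scatter) is expected.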

Compound 4, a percentage reported as inhibition, in the whole organism at one dose (the size of the read-out at that dose, not a potency): 19%
Compound 4: the middle estimate sits 9 percentage points below what was measured, and the stated range covers the measured number.
By their numbers in this assay, from the lowest: compounds 3, 2, 4 and 1 (each within the scatter of the next, the first and the last beyond it).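

For the compounds shown here, the swap of trifluoromethyl in place of methoxy gives a number 10 percentage points higher from compound 2 to compound 4 (within the scatter) in this assay and is the first comparison in this set between compounds that differ in just one place. On this aromatic carbon, ortho to a group of 9 heavy atoms, going from 2 heavy atoms to 4 and from 1 hydrogen-bond acceptor to 0 leaves the two compounds inseparable by this read-out. At this single dose, the two groups cannot be told apart here, although one pair sets no rule for other groups.

Nothing available here accounts for this outcome. On these data alone, it remains open whether an amine, a carboxylic acid or a longer chain on the same aromatic carbon would give a number beyond the scatter of compound 2.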